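This account rests on a few compounds, and the source may have more. Where it says the series, first, only, none or still open, it means among the compounds named here.

Measured so far in a functional assay on SN12C cells (Homo sapiens) for inhibition, read by sulforhodamine B assay, with a stated time of 48 h; on this read-out lower numbers stand for stronger inhibition of growth and higher numbers for weaker inhibition of growth:

Compound 1 `Nc1cc(N)c2nc(-c3ccccc3)c(NCc3ccc(Cl)c(Cl)c3)nc2c1` gives 6030 nM.
Compound 2 `Nc1cc(N)c2nc(-c3ccccc3)c(NCc3ccc(F)cc3)nc2c1` gives 7590 nM.
Compound 3 `COc1ccc(CNc2nc3cc(N)cc(N)c3nc2-c2ccccc2)cc1` gives 17000 nM.

Compound 2 stands second highest of the three; the nearer step is a 1.3-fold higher number from compound 1 to compound 2 (0.10 log units; within the scatter), while the further one is a 2.2-fold higher number from compound 2 to compound 3 (0.35 log units; beyond the scatter). Compound 4 `Nc1cc(N)c2nc(-c3ccccc3)c(Sc3ccc(Cl)c(Cl)c3)nc2c1` is not yet measured. It differs from compound 2 by (3,4-dichlorophenyl)sulfanyl in place of (4-fluorobenzyl)amino on an aromatic carbon. Of the measured steps, only a 1.3-fold higher number from compound 1 to compound 2 (0.10 log units; within the scatter) bears on it, through the dichloro-for-fluoro part of the change, and it was small. Within the data shown here, no measured step covers the exchange of the (4-fluorobenzyl)amino linker for a sulfanyl linker, so that part is uncovered. Compound 4 is therefore expected at 7000 nM in this assay, within 2500 nM to 20000 nM, an expected step of a 1.1-fold lower number from compound 2 to compound 4 (0.04 log units; within the scatter).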

Compound 4, concentration for 50% growth inhibition: 7590 nM
Estimate against measurement, compound 4: 1.1-fold (0.04 log units) below, within the range that was stated.
By their numbers in this assay, from the lowest: compounds 1, 2 and 4 (each within the scatter of the next); then compound 3.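

In this assay, among these compounds, the swap at this aromatic carbon gives no change at the digits printed from compound 2 to compound 4 (within the scatter), so the first change to the linker, not just to the aryl ring, leaves the number within the scatter. The step combines a sulfanyl linker, with 0 hydrogen-bond donors against 1, and a new aryl substitution, so the contribution of each cannot be separated. Nothing available explains this result.

Still open, going by these compounds, is whether a sulfanyl linker bearing 4-fluorophenyl or 4-methoxyphenyl would behave as the amino-linked compounds do. An ether oxygen linker or a longer chain at this position also remains untested in the compounds shown.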